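The source may hold more compounds than are shown below. What is called first, only, known or untested is meant among the compounds shown, and "the series" means these compounds.

Series notes. Compound 1 `CCc1cccc2c(=O)c(-c3nn[nH]n3)c[nH]c12` carries an ethyl group on the shared core, and in a functional assay on the whole organism (strain Sprague-Dawley) for inhibition, with Rattus norvegicus as the target (on this read-out higher numbers stand for an effect only at larger amounts of compound and lower numbers for an effect already at smaller amounts), compound 1 gives 0.312 mg/kg. Compound 2 `Cc1cccc2c(=O)c(-c3nn[nH]n3)c[nH]c12` stands at the weaker end of the two values shown. For compound 2 the assay reports only a limit, > 5 mg/kg. For the measured compounds named here, the one measured step, an at least 16-fold higher number from compound 1 to compound 2 (1.20 log units; beyond the scatter), rests on (the limit of > 5 mg/kg in this assay, at which 1 of the 2 values shown sits). Compound 3 `CC(C)Oc1cccc2c(=O)c(-c3nn[nH]n3)c[nH]c12` differs from compound 2 by isopropoxy in place of methyl on an aromatic carbon. Read in reverse, that step points downward; a lower number for compound 3 is therefore expected, an at least 4.0-fold lower number from compound 2 to compound 3 (0.60 log units; beyond the scatter). Compound 3 is estimated at 1.25 mg/kg, within 0.3 mg/kg to 5 mg/kg.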

Compound 3, minimum effective dose: 0.078 mg/kg
Estimate against measurement, compound 3: 16-fold (1.20 log units) above, and the stated range ends above it.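

Isopropoxy in place of ethyl gives a 4.0-fold lower number from compound 1 to compound 3 (0.60 log units; beyond the scatter), so on this aromatic carbon a group linked through oxygen goes beyond the ethyl group in this assay, and the position is not confined to plain alkyl groups. Against methyl the change gives an at least 64-fold lower number from compound 2 to compound 3 (1.80 log units; beyond the scatter), a step whose size is only a bound and which rests on a limit for compound 2: the limit of > 5 mg/kg in this assay, at which 1 of the 3 values shown sits.

The compounds shown do not separate the oxygen of isopropoxy from its branching. Methoxy, ethoxy or propyl on this aromatic carbon would bear on that, and an amine there also remains open.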